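The compounds below may be only part of what the source reports. "The series", "measured", "known", "first", "only" and "open" are said of these compounds alone.

Measured so far in a physicochemical assay for lipophilicity, in phosphate buffer, measured as octanol-water partition, at pH 7.4; on this read-out lower numbers stand for lower lipophilicity and higher numbers for higher lipophilicity
- compound 1 `CC(C)N1CC2(CCN(CC(O)C3COc4ccccc4O3)CC2)OC1=O` gives 2.05
- compound 2 `O=C1NC(c2ccccc2)C2(CCN(CC(O)C3COc4ccccc4O3)CC2)O1` gives 2.41

Compound 2 stands higher of the two, with compound 1 lower by a gap beyond the scatter. Compound 3 `O=C1NC(Cc2ccccc2)C2(CCN(CC(O)C3COc4ccccc4O3)CC2)O1` is not yet measured. It carries benzyl in place of phenyl on a saturated ring carbon. Among the measured compounds shown here, no measured pair differs in one place, and the expectation rests on this change alone. A small upward step in this assay is expected, of a size within the scatter (a number 0.24 log units higher from compound 2 to compound 3 (within the scatter)). Compound 3 is estimated at 2.65 (expected range 2.2 to 3.1).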

Compound 3, distribution coefficient: 2.41
For compound 3 the middle estimate is 0.24 log units above the measured one; low and high end bracket the measured number.
By their numbers in this assay, from the lowest: compound 1; then compounds 2 and 3 (each within the scatter of the next).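

Across this position, this assay gives no change at the digits printed from compound 2 to compound 3 (within the scatter) for benzyl in place of phenyl on a saturated ring carbon. Among the compounds shown here, this is the first comparison that differs in one place, and it shows that this change leaves the read-out flat on the shared core. Nothing on hand accounts for this flat step.

Still open, going by these compounds, is whether a longer chain such as phenylethyl at this carbon would move the read-out. The same applies to an amine or a carboxylic acid on the aromatic ring of the benzyl group.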